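Alkylating the indole nitrogen of a cytotoxic quinone core

The source may report more compounds than this note shows. Statements on the series, on what has been measured and on what is new or still open speak of the compounds shown alone.

Compound 1 `O=C1c2c[n+]([O-])c3ccccc3c2C(=O)c2[nH]c3ccccc3c21` is the parent of this small set. In a toxicity assay on HEK-293T cells (Homo sapiens) for cytotoxicity, read by MTT assay, with a stated time of 72 h (on this read-out higher numbers stand for weaker inhibition and lower numbers for stronger inhibition), compound 1 gives 890 nM, the lowest of the three numbers; compound 3 `O=C1c2c[n+]([O-])c3ccccc3c2C(=O)c2c1c1ccccc1n2Cc1cn([C@H]2O[C@H](CO)[C@@H](O)[C@H]2O)nn1` gives 1370 nM, within the scatter of compound 1, while compound 2 `CC1(C)OCC(Cn2cc(Cn3c4c(c5ccccc53)C(=O)c3c[n+]([O-])c5ccccc5c3C4=O)nn2)O1` gives 5510 nM, a clearly higher number. Within the data shown here, the single step that can be measured, a 4.0-fold lower number from compound 2 to compound 3 (0.60 log units; beyond the scatter), concerns the group carried on the aromatic nitrogen, not the bare nitrogen itself. Compound 4 `CN1CCN(CCCn2c3c(c4ccccc42)C(=O)c2c[n+]([O-])c4ccccc4c2C3=O)CC1` differs from compound 1 by 3-(4-methylpiperazin-1-yl)propyl in place of hydrogen on an aromatic nitrogen. Both compounds bearing a substituent on that nitrogen show higher numbers than compound 1, so a modest rise is expected for compound 4, as a 2.2-fold higher number from compound 1 to compound 4 (0.35 log units; beyond the scatter). Compound 4 is therefore estimated at 2000 nM, within a range of 700 nM to 6000 nM.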

Compound 4, half-maximal inhibitory concentration: 170 nM
The estimate for compound 4 lay 12-fold (1.07 log units) above the measured number, and the stated range ends above it.
By their numbers in this assay, from the lowest: compound 4; then compounds 1 and 3 (each within the scatter of the next); then compound 2.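

In this assay, the step of a 5.2-fold lower number from compound 1 to compound 4 (0.72 log units; beyond the scatter) shows that a substituent on this aromatic nitrogen can lower the number, not only leave it level or raise it. Replacing hydrogen with 3-(4-methylpiperazin-1-yl)propyl therefore places compound 4 beyond the scatter of compound 1. No evidence is available to explain this step. The compounds shown leave open whether the piperazine ring or the propyl chain matters more. A morpholine or a dimethylamine at the end of the chain, or a longer chain, would separate these two parts.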